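The source may hold more compounds than are shown below. What is called first, only, known or untested is meant among the compounds shown, and "the series" means these compounds.

Working notes on the series. Compound 3 `O=S(=O)(c1ccc(F)c(Cl)c1)c1cnc2c(F)cccc2c1-c1cccc(F)c1` gives 1.23 mL/min in an ADME assay on microsomes from liver (Homo sapiens) for metabolic stability, tested at 2.5 uM; a lower number here means slower removal, a higher number faster removal of the compound. Among the three measured compounds it sits second highest, with compound 2 `N#Cc1cccc(S(=O)(=O)c2cnc3c(F)cccc3c2-c2cccc(Cl)c2)c1` nearest at 1.11 mL/min and compound 1 `O=S(=O)(c1ccc(F)cc1)c1cnc2c(F)cccc2c1-c1cccc(F)c1` furthest at 1.56 mL/min; both gaps are within the scatter, so the three compounds cannot be separated in this assay. For the measured compounds named here, the one single-point step available, a 1.3-fold lower number from compound 1 to compound 3 (0.10 log units; within the scatter), also lies within the scatter.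

Compound 4 `N#Cc1cccc(S(=O)(=O)c2cnc3c(F)cccc3c2-c2cccc(F)c2)c1` is the next compound to be measured. The change from compound 3 to compound 4 is 3-cyanophenyl in place of 3-chloro-4-fluorophenyl on a sulfonyl sulfur. Going by the values given here, no measured pair carries this exact change, so the step from compound 1 to compound 3 bears on it only in showing how little this position has moved the number so far. Compound 2 carries the same 3-cyanophenyl on the sulfonyl sulfur and gives 1.11 mL/min, close to compound 3. Compound 4 is therefore expected to show no step beyond the scatter, a 1.1-fold lower number from compound 3 to compound 4 (0.03 log units; within the scatter). The estimate for compound 4 in this assay is 1.15 mL/min, with a range of 0.7 mL/min to 1.9 mL/min.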

Compound 4, intrinsic clearance in a liver preparation (reported as CLH), per the amount of preparation that the assay uses: 0.34 mL/min
The estimate for compound 4 lay 3.4-fold (0.53 log units) above the measured number, outside the stated range (below it).
By their numbers in this assay, from the lowest: compound 4; then compounds 2, 3 and 1 (each within the scatter of the next).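

The sulfonyl sulfur position, which so far had given only a 1.3-fold lower number from compound 1 to compound 3 (0.10 log units; within the scatter), can move the number in this assay: 3-cyanophenyl in place of 3-chloro-4-fluorophenyl gives a 3.6-fold lower number from compound 3 to compound 4 (0.56 log units; beyond the scatter), and in place of 4-fluorophenyl it gives a 4.6-fold lower number from compound 1 to compound 4 (0.66 log units; beyond the scatter). The 3-cyanophenyl group alone does not go with a low number, as compound 2 carries it too, and fluoro in place of chloro on an aromatic carbon gives a 3.3-fold lower number from compound 2 to compound 4 (0.51 log units; beyond the scatter); the low number appears only where the two features occur together, in compound 4. Nothing measured here accounts for the drop.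

Open, as far as these compounds go, is whether fluoro in place of chloro lowers the number in compounds without the nitrile, so whether the two changes depend on each other cannot be told. Also open, from the compounds shown here alone, is whether an amide or a carboxylic acid in place of the nitrile would keep the number this low.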